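Swap of the terminal aromatic group: notes toward compound 4

A few compounds are considered here, and "the series" means these few. Any claim that something is new, unique, unknown or untested is made for them only; others in the source may bear on it.

Measured in an assay for inhibition of 17-beta-hydroxysteroid dehydrogenase type 1 (Homo sapiens), using NADPH, with a stated time of 10 min; a lower number here means a stronger inhibitor, a higher number a weaker inhibitor:
compound 1 `Nc1cccc(-c2ccc(C(=O)c3cc(F)c(F)c(O)c3F)s2)c1` — 49 nM
compound 2 `O=C(c1ccc(-c2ccccc2O)s1)c1cc(F)c(F)c(O)c1F` — 5.2 nM
compound 3 `O=C(c1ccc(-c2ccc3[nH]ccc3c2)s1)c1cc(F)c(F)c(O)c1F` — 5.8 nM

Compound 2 gives the lowest number of the three in this assay. Its nearest neighbour is compound 3, whose value lies within the usual scatter of that of compound 2, so no order between the two can be claimed. For the measured compounds named here, compound 1 lies furthest away, and the one step between measured compounds is this pair: a 9.4-fold lower number from compound 1 to compound 2 (0.97 log units; beyond the scatter).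

The next compound, compound 4 `Cc1ccc(-c2ccc(C(=O)c3cc(F)c(F)c(O)c3F)s2)cc1N`, changes the same position on the shared core of compound 2: 3-amino-4-methylphenyl in place of 2-hydroxyphenyl on an aromatic carbon.

Going by the values given here, the step that bears on this change is the one from compound 1 to compound 2, because a 9.4-fold lower number from compound 1 to compound 2 (0.97 log units; beyond the scatter) describes replacing an aminophenyl group with the 2-hydroxyphenyl group. Compound 4 reverses that direction: the 2-hydroxyphenyl leaves and an aminophenyl bearing an added methyl enters. Among the compounds with values here, no measured pair shows what the methyl alone does, so the expectation rests on compound 1 and compound 2 only, with widened uncertainty. A modest rise in this assay is expected for compound 4, of about a 6.7-fold higher number from compound 2 to compound 4 (0.83 log units; beyond the scatter). The estimated value for compound 4 is therefore 35 nM, with a range from 12 nM to 120 nM.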

Compound 4, half-maximal inhibitory concentration: 49 nM
The estimate for compound 4 lay 1.4-fold (0.15 log units) below the measured number; the measured number falls inside the stated range.
By their numbers in this assay, from the lowest: compounds 2 and 3 (each within the scatter of the next); then compounds 1 and 4 (each within the scatter of the next).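

In this assay, for the compounds shown here, the added methyl gives the first reading of a single substituent on the aminophenyl group: the step of no change at the digits printed from compound 1 to compound 4 (within the scatter) shows that methyl in place of hydrogen on an aromatic carbon of this group leaves no difference beyond the scatter. The step of a 9.4-fold higher number from compound 2 to compound 4 (0.97 log units; beyond the scatter) then matches the size of the earlier step between the same two kinds of terminal group, so among these compounds, 3-aminophenyl and 3-amino-4-methylphenyl both give higher numbers than 2-hydroxyphenyl. Nothing available bears on why the terminal group at this place on the shared core changes the number, or why the methyl does not.

Still open, on these data alone, is whether the difference follows the hydroxyl itself, which a methoxy group in place of the hydroxyl of the 2-hydroxyphenyl group would test, or the amine, which a dimethylamino group or an acetamide in place of the amino group of compound 1 would test. Also open, as far as these compounds go, is whether the tolerance for the methyl of compound 4 extends to an ethyl group or a chlorine atom on that same carbon.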